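The source may hold more compounds than are shown below. What is called first, only, known or untested is meant among the compounds shown, and "the series" means these compounds.

Compound 3 `O=C(N/N=C/c1cccc(O)c1O)c1cc(-c2ccc(Cl)cc2)nn1Cc1ccc(Cl)nc1` carries the acylhydrazone of the shared core with a 6-chloropyridin-3-yl group on the saturated chain carbon bound to an aromatic nitrogen and a 2,3-dihydroxyphenyl on the hydrazone. In a functional assay on A549 cells (Homo sapiens) for antiproliferative activity, read by BrdU incorporation, with a stated time of 48 h (a lower number here means a stronger inhibitor, a higher number a weaker inhibitor), compound 3 gives 700 nM, the second highest of the three numbers. Compound 2 `CC(C)(C)c1ccc(Cn2nc(-c3ccc(Cl)cc3)cc2C(=O)N/N=C/c2cccc(O)c2O)cc1` gives 400 nM, and the step of a 1.8-fold higher number from compound 2 to compound 3 (0.24 log units; within the scatter) lies within the scatter. Compound 1 `CC(C)(C)c1ccc(Cn2nc(-c3ccc(Cl)cc3)cc2C(=N)NO)cc1`, the amidoxime, gives 17000 nM, a higher number than compound 3 by a margin beyond the scatter. Compound 4 `O=C(N/N=C/c1ccccc1O)c1cc(-c2ccc(Cl)cc2)nn1Cc1ccc(Cl)nc1` differs from compound 3 by hydrogen in place of hydroxy on an aromatic carbon. Among the measured compounds shown here, no measured step touches this position: the one single-place step, a 1.8-fold higher number from compound 2 to compound 3 (0.24 log units; within the scatter), concerns the group on the saturated chain carbon. Compounds 1 and 2 differ in more than one place, so their values do not separate one hydroxy from the other. The expectation for compound 4 is therefore loosely held: a step of a 2.1-fold higher number from compound 3 to compound 4 (0.33 log units; beyond the scatter) toward a weaker inhibitor is expected, possibly beyond the scatter. Compound 4 is estimated at 1500 nM, with a range from 500 nM to 5000 nM.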

Compound 4, half-maximal inhibitory concentration: 300 nM
Compound 4: middle estimate off by 5.0-fold (0.70 log units), on the high side; the whole stated range lies above it.
By their numbers in this assay, from the lowest: compounds 4, 2 and 3 (each within the scatter of the next, the first and the last beyond it); then compound 1.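

Among the compounds shown here, the change from 2,3-dihydroxyphenyl to 2-hydroxyphenyl gives the first single-place reading at this aromatic carbon: in this assay it gives a 2.3-fold lower number from compound 3 to compound 4 (0.37 log units; beyond the scatter) and so moves toward a stronger inhibitor. Within this pair, the hydroxy that leaves is therefore not required for antiproliferative activity, although the step is modest and has been read only with the 6-chloropyridin-3-yl group on the saturated chain carbon. No supporting measurement bears on what lies behind this step.

The compounds shown leave open whether the same change holds with the 4-(tert-butyl)phenyl group of compound 2. They also leave open what a methoxy group or an amine would do at this aromatic carbon, and whether the remaining hydroxy can be replaced by hydrogen.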